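Methoxy in place of trifluoromethyl: compound 3 to compound 4

The source may hold more compounds than are shown below. What is called first, only, known or untested is meant among the compounds shown, and "the series" means these compounds.

Compound 3 `O=C(/C=C\Nc1ccc(C(F)(F)F)cc1)c1cn(-c2ccccc2)nc1-c1ccc(Cl)cc1` returns in a functional assay on HT-29 cells (Homo sapiens) for antiproliferative activity, read by MTT assay, with a stated time of 48 h (on this read-out lower numbers stand for stronger inhibition and higher numbers for weaker inhibition), only a limit, > 50000 nM. Compound 2 `O=C(/C=C\Nc1ccc(F)cc1)c1cn(-c2ccccc2)nc1-c1ccc(Cl)cc1` likewise returns only the limit > 50000 nM in this assay. The step that the two limits leave unreadable from compound 2 to compound 3 therefore has no readable size, and the limit of > 50000 nM in this assay, at which 2 of the 3 values shown sit, caps what the chloro pair can tell. Going by the values given here, compound 1 `COc1ccc(N/C=C\C(=O)c2cn(-c3ccccc3)nc2-c2ccc(F)cc2)cc1` is the only member with a number in this assay, giving 3200 nM. Compound 4 `COc1ccc(N/C=C\C(=O)c2cn(-c3ccccc3)nc2-c2ccc(Cl)cc2)cc1` arises from compound 3 by methoxy in place of trifluoromethyl on an aromatic carbon; it pairs the methoxy anilino part of compound 1 with the chloro aryl part of compound 3. Among the compounds with values here, no measured step covers this change directly. Compound 1 with 3200 nM hints that compound 4 may come into range in this assay. The step to compound 4 is expected, an at least 6.2-fold lower number from compound 3 to compound 4 (0.79 log units; beyond the scatter), to run toward stronger inhibition, its size uncertain. Compound 4 is expected to give 8000 nM, within 2000 nM to 50000 nM.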

Compound 4, half-maximal inhibitory concentration: 8930 nM
Estimate against measurement, compound 4: 1.1-fold (0.05 log units) below; the measured number falls inside the stated range.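

Of the three groups shown at this aromatic carbon, only methoxy brings the chloro aryl series to a number in this assay, with an at least 5.5-fold lower number from compound 3 to compound 4 (0.74 log units; beyond the scatter) and an at least 5.5-fold lower number from compound 2 to compound 4 (0.74 log units; beyond the scatter). With methoxy held, chloro in place of fluoro on the other aryl part gives a 2.8-fold higher number from compound 1 to compound 4 (0.45 log units; beyond the scatter), so both halogens tolerate a measurable value. The step between fluoro and trifluoromethyl cannot be read: the limit of > 50000 nM in this assay, at which 2 of the 4 values shown sit.

Open, as far as these compounds go, is whether a hydroxyl, an amine or a longer alkoxy chain at this carbon would match methoxy. From the compounds shown here alone, the true size of the methoxy steps also stays open.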